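Swapping Methoxy for Fluoro on the Shared Core

The source may report more compounds than this note shows. Statements on the series, on what has been measured and on what is new or still open speak of the compounds shown alone.

In an assay on isolated protein for displacement of a labelled ligand from metabotropic glutamate receptor 5 (Homo sapiens), with a stated time of 60 min, tested at 1 uM (a higher number here means more inhibition at the concentration tested (going by the name of the read-out), a lower number less inhibition), compound 1 `COc1ccc2ncc(S(=O)(=O)c3ccc(Cl)c(Cl)c3)c(N3CCC(C)CC3)c2c1` gives 87%. Of the three measured compounds it stands second highest. The step of a number 4 percentage points higher from compound 1 to compound 2 (within the scatter) lies within the scatter; compound 2 `COc1ccc2ncc(S(=O)(=O)c3ccc(Cl)cc3)c(N3CCC(C)CC3)c2c1` gives 91%. The step of a number 87 percentage points lower from compound 1 to compound 3 (beyond the scatter) is large; compound 3 `COc1cccc(S(=O)(=O)c2cnc3ccc(OC)cc3c2N2CCC(C)CC2)c1` gives 0%. Compound 4 `CC1CCN(c2c(S(=O)(=O)c3ccc(Cl)c(Cl)c3)cnc3ccc(F)cc23)CC1` differs from compound 1 by fluoro in place of methoxy on an aromatic carbon. Both measured steps change only the group on the sulfonyl sulfur, so none of them bears directly on this change on the shared core, and the data give no basis for expecting a shift beyond the scatter. The expected step is a number 7 percentage points lower from compound 1 to compound 4 (within the scatter). Compound 4 is estimated at 80%, within a range from 50% to 96%.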

Compound 4, a percentage reported as inhibition, at one concentration (the size of the read-out at that concentration, not a potency): 91%
Compound 4: middle estimate off by 11 percentage points, on the low side; measured number inside the range.
By their numbers in this assay, from the lowest: compound 3; then compounds 1, 2 and 4 (each within the scatter of the next).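

Fluoro in place of methoxy on an aromatic carbon of the shared core gives a number 4 percentage points higher from compound 1 to compound 4 (within the scatter) in this assay. Among the compounds shown here, with 3,4-dichlorophenyl on the sulfonyl sulfur, the methoxy group is therefore not needed to keep this level of inhibition, whereas the earlier compounds showed only changes at the sulfonyl sulfur. No measurement available here explains why the two groups read alike. As far as these compounds go, it remains open whether an amine or a carboxylic acid at this position would also keep the inhibition, and whether fluoro would restore any inhibition with the 3-methoxyphenyl group of compound 3.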